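Moving the halogen back to the para position, now as bromine

This account rests on a few compounds, and the source may have more. Where it says the series, first, only, none or still open, it means among the compounds named here.

Two closely related compounds have been measured in a functional assay on MKN-45 cells (Homo sapiens) for cytotoxicity, read by MTT assay, with a stated time of 72 h; a higher number here means a weaker inhibitor, a lower number a stronger inhibitor. Compound 1 `COc1cc2c(Oc3ccc(NC(=O)c4nn(-c5ccc(F)cc5)c(=O)c5ccccc45)cc3F)ccnc2cc1OCCCN1CCN(C)CC1` carries a 4-fluorophenyl on an aromatic nitrogen of its shared core, and in this assay compound 1 gives 150 nM. Compound 2 `COc1cc2c(Oc3ccc(NC(=O)c4nn(-c5ccccc5F)c(=O)c5ccccc45)cc3F)ccnc2cc1OCCCN1CCN(C)CC1` differs only in that the fluorine sits elsewhere on that phenyl ring, and in this assay compound 2 gives 210 nM. Among the two numbers, compound 2 has the higher one, though the step of a 1.4-fold higher number from compound 1 to compound 2 (0.15 log units; within the scatter), so the two cannot be told apart on these data.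

Compound 3 `COc1cc2c(Oc3ccc(NC(=O)c4nn(-c5ccc(Br)cc5)c(=O)c5ccccc45)cc3F)ccnc2cc1OCCCN1CCN(C)CC1` is the next member of this small set. The change from compound 2 is 4-bromophenyl in place of 2-fluorophenyl on an aromatic nitrogen. For the measured compounds named here, only one measured step bears on this change, the one from compound 1 to compound 2, and it stayed within the scatter. Nothing here speaks for a shift beyond that scatter, so the expected step of a 1.2-fold lower number from compound 2 to compound 3 (0.09 log units; within the scatter) is modest. Compound 3 is therefore estimated at 170 nM, with a likely range from 70 nM to 420 nM.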

Compound 3, half-maximal inhibitory concentration: 350 nM
Beside the measured number, compound 3's estimate is 2.1-fold (0.31 log units) below it, within the range that was stated.
By their numbers in this assay, from the lowest: compounds 1, 2 and 3 (each within the scatter of the next, the first and the last beyond it).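

The clearest comparison here is between 4-fluorophenyl and 4-bromophenyl. For the compounds shown here, only the halogen differs between them: in this assay, bromo in place of fluoro on an aromatic carbon gives a 2.3-fold higher number from compound 1 to compound 3 (0.37 log units; beyond the scatter) and is the first step in this small set to pass the scatter, though only modestly. The other new comparison, a 1.7-fold higher number from compound 2 to compound 3 (0.22 log units; within the scatter), changes both the halogen and where it sits on the phenyl ring, and it does not separate those two compounds. So this position has now shown some sensitivity to which halogen the ring carries, but nothing measured alongside these numbers accounts for that step.

The compounds shown leave open what 4-chlorophenyl would give in this assay, and so whether any steady trend runs through the halogens on this ring. Also open, from the compounds shown here alone, are whether 2-bromophenyl would stand apart from 2-fluorophenyl as 4-bromophenyl does from 4-fluorophenyl, and how a phenyl ring carrying an amine or a carboxylic acid instead of a halogen would read.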